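The source may report more compounds than this note shows. Statements on the series, on what has been measured and on what is new or still open speak of the compounds shown alone.

Measured compounds in a functional assay on HCT-116 cells (Homo sapiens) for antiproliferative activity, read by MTT assay, with a stated time of 72 h; a higher number here means a weaker inhibitor, a lower number a stronger inhibitor:
compound 1 `CO[C@@H]1C[C@@H]2O[C@@]2(C)C(=O)N(C)[C@@H](C(C)C)C(=O)N[C@H](Cc2cc(Cl)c(O)c(Cl)c2)C(=O)N[C@@H](C(C)(C)O)C(=O)O[C@H](c2ccccc2)[C@H](C)/C=C/C=C/1C` gives 6.7 nM
compound 2 `CC[C@H](C)[C@H]1C(=O)N[C@H](Cc2ccccc2)C(=O)N[C@@H](C(C)(C)O)C(=O)O[C@H](c2ccccc2)[C@H](C)/C=C/C=C(\C)[C@H](OC)C[C@@H]2O[C@@]2(C)C(=O)N1C` gives 20.9 nM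
compound 3 `COc1cc(C[C@H]2NC(=O)[C@H](C(C)C)N(C)C(=O)/C(C)=C/C[C@@H](OC)/C(C)=C/C=C/[C@@H](C)[C@@H](c3ccccc3)OC(=O)[C@H](C(C)C)NC2=O)ccc1O` gives 48.5 nM

Compound 2 stands second highest of the three numbers: nearest to compound 3, whose number is higher by a gap beyond the scatter, and furthest from compound 1, whose number is lower, again beyond the scatter. Compound 4 `CC[C@H](C)[C@H]1C(=O)N[C@H](Cc2ccc(O)c(OC)c2)C(=O)N[C@@H](C(C)(C)O)C(=O)O[C@H](c2ccccc2)[C@H](C)/C=C/C=C(\C)[C@H](OC)C[C@@H]2O[C@@]2(C)C(=O)N1C` is unmeasured. It differs from compound 2 in one place: 4-hydroxy-3-methoxyphenyl in place of phenyl on a saturated chain carbon bound to a saturated ring carbon. Within the data shown here, no step between measured compounds isolates this change; compound 1 carries a different substituted phenyl and compound 3 a different core. The step of a 1.4-fold lower number from compound 2 to compound 4 (0.14 log units; within the scatter) is expected to be small, if anything toward a lower number, and may not exceed the scatter. Compound 4 is estimated at 15 nM, with a range from 5 nM to 45 nM.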

Compound 4, half-maximal inhibitory concentration: 25.2 nM
For compound 4 the middle estimate is 1.7-fold (0.23 log units) below the measured one; low and high end bracket the measured number.
By their numbers in this assay, from the lowest: compound 1; then compounds 2, 4 and 3 (each within the scatter of the next, the first and the last beyond it).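

In this assay, among these compounds, the change reads as a 1.2-fold higher number from compound 2 to compound 4 (0.08 log units; within the scatter) and gives the first direct reading at this position, on an unchanged core. Replacing phenyl with 4-hydroxy-3-methoxyphenyl on a saturated chain carbon bound to a saturated ring carbon is tolerated here, with the added hydroxy and methoxy groups leaving the number within the scatter. No measured evidence bears on this result.

As far as these compounds go, whether the hydroxy or the methoxy group alone would behave the same remains open. So does the outcome with an amine or a carboxylic acid on the phenyl ring.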